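A few compounds are considered here, and "the series" means these few. Any claim that something is new, unique, unknown or untested is made for them only; others in the source may bear on it.

Measured so far in an assay on HEK293 cells for displacement of a labelled ligand from 5-hydroxytryptamine receptor 7 (Homo sapiens), read by scintillation counting, with a stated time of 30 min; a higher number here means a weaker inhibitor, a lower number a stronger inhibitor:

Compound 1, `Oc1cccc(NCCN2CCN(c3ccccc3)CC2)c1`: 252 nM
Compound 2, `CN(CCCN1CCN(c2ccccc2)CC1)c1cccc(Cl)c1`: 179 nM
Compound 3, `Oc1cccc(NCCCN2CCN(c3ccccc3)CC2)c1`: 10.1 nM

Compound 2 stands second highest of the three numbers in this assay. Its nearest neighbour is compound 1, whose number lies within the usual scatter of that of compound 2, so no order between these two can be read from the data. Compound 3 lies far lower, well beyond the scatter; it differs from compound 2 in more than one place, so no single change can be tied to that gap.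

Compound 4, `CN(CCCN1CCN(c2ccccc2)CC1)c1cccc(NS(C)(=O)=O)c1`, has not yet been measured. It is compound 2 with methanesulfonamido in place of chloro on an aromatic carbon. Going by the values given here, no measured pair isolates this exchange, so its effect cannot be taken from a known step. The expectation is a modest step, if any, towards a lower number; the estimated step is a 1.6-fold lower number from compound 2 to compound 4 (0.21 log units; within the scatter). Compound 4 is therefore expected to give about 110 nM in this assay, with a range of 30 nM to 450 nM.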

Compound 4, inhibition constant: 39.6 nM
Compound 4: middle estimate off by 2.8-fold (0.44 log units), on the high side; low and high end bracket the measured number.
By their numbers in this assay, from the lowest: compound 3; then compound 4; then compounds 2 and 1 (each within the scatter of the next).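

In this assay, going by these compounds alone, methanesulfonamido in place of chloro on an aromatic carbon, meta to a large group, gives a 4.5-fold lower number from compound 2 to compound 4 (0.66 log units; beyond the scatter), the only single change so far that can be read directly. The step lies beyond the scatter, so the group at this place does bear on the number, and the larger entering group, with its hydrogen-bond donor and acceptors, is tolerated here without any loss. Nothing measured on hand says which feature of the entering group accounts for the step.

Open, going by these compounds, is whether a similar step would follow from other groups at this place, such as acetamido, an amine or a carboxylic acid. Also open, on these data alone, is whether the amide hydrogen matters, which the methanesulfonamido group carrying a methyl on its nitrogen would test.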